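The source may report more compounds than this note shows. Statements on the series, on what has been measured and on what is new or still open speak of the compounds shown alone.

Among the compounds with values here, in a toxicity assay on MT4 cells (Homo sapiens) for cytotoxicity, read by MTT assay (on this read-out higher numbers stand for lower toxicity in this test and lower numbers for higher toxicity in this test), compound 1 `Cc1cc(-c2ccc(C#N)c(C#N)c2)ccc1Oc1cc(N)nc(Nc2ccc(C#N)cc2)n1` gives 76700 nM, the highest number of the three measured so far. Compound 2 `Cc1cc(-c2ccccc2C#N)cc(C)c1Oc1cc(N)nc(Nc2ccc(C#N)cc2)n1` gives 25400 nM, and compound 3 `Cc1cc(-c2ccc(C#N)c(C#N)c2)cc(C)c1Oc1cc(N)nc(Nc2ccc(C#N)cc2)n1` gives 17600 nM. Compound 4 `Cc1cc(-c2ccc(F)cc2)ccc1Oc1cc(N)nc(Nc2ccc(C#N)cc2)n1` has not been measured and differs from compound 1 at one place: 4-fluorophenyl in place of 3,4-dicyanophenyl on an aromatic carbon. This is 4-fluorophenyl in place of 3,4-dicyanophenyl on an aromatic carbon.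

Within the data shown here, two measured steps bear on it. Among the measured compounds shown here, the only aryl exchange available is a 1.4-fold lower number from compound 2 to compound 3 (0.16 log units; within the scatter), and it involves 2-cyanophenyl rather than 4-fluorophenyl. For the measured compounds named here, the other, a 4.4-fold lower number from compound 1 to compound 3 (0.64 log units; beyond the scatter), is methyl in place of hydrogen at a different place, so it shows only that the number can move. No measurement tests 4-fluorophenyl directly. With compound 1 at 76700 nM, the top of the measured range, a lower number is the likelier direction in this assay, but only a small step is expected. The expected step is a 1.7-fold lower number from compound 1 to compound 4 (0.23 log units; within the scatter). Compound 4 is estimated at 45000 nM, with an expected range of 15000 nM to 100000 nM.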

Compound 4, half-maximal cytotoxic concentration: 20100 nM
The estimate for compound 4 lay 2.2-fold (0.35 log units) above the measured number; the range from low to high includes it.
By their numbers in this assay, from the lowest: compounds 3, 4 and 2 (each within the scatter of the next); then compound 1.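

In this assay the aryl group on this carbon proves able to move the number beyond the scatter, with a 3.8-fold lower number from compound 1 to compound 4 (0.58 log units; beyond the scatter) on the exchange of 3,4-dicyanophenyl for 4-fluorophenyl. Within the data shown here, the only earlier aryl exchange, a 1.4-fold lower number from compound 2 to compound 3 (0.16 log units; within the scatter) on a different background, stayed within the scatter, so the earlier compounds showed no such sensitivity at this position. Nothing measured here explains the shift.

The exchange removes both nitriles and brings in fluorine in one step, so the compounds shown do not separate the two, and an unsubstituted phenyl would be needed to do so. Also open, going by these compounds, are how an amine or a carboxylic acid on this aryl ring would read, and whether 4-fluorophenyl gives a similar number with the second methyl group present.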